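The source may report more compounds than this note shows. Statements on the series, on what has been measured and on what is new or still open speak of the compounds shown alone.

Measured so far in a physicochemical assay for solubility; a lower number here means a less soluble compound, a higher number a more soluble compound:
Compound 1 `Cn1nccc1-c1cc(C(F)(F)F)ccc1[C@H]1CCOc2cc(S(=O)(=O)Nc3ccncn3)ccc21` gives 1180000 nM
Compound 2 `Cn1nccc1-c1cc(C(F)(F)F)ccc1[C@H]1CCOc2cc(S(=O)(=O)Nc3nccs3)ccc21` gives 83000 nM
Compound 3 `Cn1nccc1-c1cc(C(F)(F)F)ccc1[C@H]1CCOc2cc(S(=O)(=O)Nc3ncccn3)ccc21` gives 532000 nM

All three share one core and differ only in the group on the sulfonamide nitrogen. Compound 2 stands lowest of the three in this assay: a 6.4-fold higher number from compound 2 to compound 3 (0.81 log units; beyond the scatter), and a 14-fold lower number from compound 1 to compound 2 (1.15 log units; beyond the scatter).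

Compound 4 `Cc1nc(-c2cc(C(F)(F)F)ccc2[C@H]2CCOc3cc(S(=O)(=O)Nc4nccs4)ccc32)co1` changes a different part of compound 2: 2-methyl-1,3-oxazol-4-yl in place of 1-methyl-1H-pyrazol-5-yl on an aromatic carbon. Among the compounds with values here, none of the measured steps touches that position; they all concern the sulfonamide nitrogen, so none bears directly on this change. Within the data shown here, with no comparable step in hand, no move beyond the usual scatter is expected in this assay, in either direction. Compound 4 is therefore estimated at 83000 nM, within a range of 28000 nM to 250000 nM, which means an expected no change at the digits printed from compound 2 to compound 4 (within the scatter).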

Compound 4, solubility: 61000 nM
Compound 4: the middle estimate sits 1.4-fold (0.13 log units) above what was measured; measured number inside the range.
By their numbers in this assay, from the lowest: compounds 4 and 2 (each within the scatter of the next); then compound 3; then compound 1.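

Within the data shown here, the position on an aromatic carbon ortho to a large group, meta to a trifluoromethyl group, is tested here for the first time. In this assay the swap from 1-methyl-1H-pyrazol-5-yl to 2-methyl-1,3-oxazol-4-yl gives a 1.4-fold lower number from compound 2 to compound 4 (0.13 log units; within the scatter), so at this position one five-membered aromatic ring can replace the other with no change beyond the scatter, unlike the steps at the sulfonamide nitrogen. No measurement at hand explains this result. Still open, as far as these compounds go, is whether an amine or a carboxylic acid at this position would shift the number, and whether the same swap behaves alike with pyrimidin-4-yl on the sulfonamide nitrogen.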